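Methyl for Propargyl on Sulfur: a Step Expected Small

This account rests on a few compounds, and the source may have more. Where it says the series, first, only, none or still open, it means among the compounds named here.

Of the compounds shown here, three have been tested in a functional assay on SW707 cells (Homo sapiens) for cytotoxicity, read by sulforhodamine B assay, with a stated time of 72 h; a lower number here means a stronger inhibitor, a higher number a weaker inhibitor. Compound 1 `C[Se]c1c(SCC#CCO)cnc2ccccc12` gives 3.5 ug/mL. Compound 2 `C#CC[Se]c1c(SCC#CCO)cnc2ccccc12` gives 3.8 ug/mL. Compound 3 `C#CCSc1cnc2ccccc2c1[Se]CC#CCO` gives 3.3 ug/mL. Compound 1 arises from compound 2 by hydrogen in place of ethynyl on a saturated chain carbon bound to a selenium atom, and this step gave a 1.1-fold lower number from compound 2 to compound 1 (0.04 log units; within the scatter). How the core of compound 3 differs from that of compound 2 is not broken down here. Compound 4 `CSc1cnc2ccccc2c1[Se]CC#CCO` has not yet been measured; it arises from compound 3 by hydrogen in place of ethynyl on a saturated chain carbon bound to a sulfur. Within the data shown here, this is the same kind of change as the one from compound 2 to compound 1, but the place differs: there the saturated chain carbon is bound to a selenium atom, here it is bound to a sulfur. Since the step of a 1.1-fold lower number from compound 2 to compound 1 (0.04 log units; within the scatter) stayed within the scatter, a step of similar size is expected for compound 4, namely a 1.0-fold higher number from compound 3 to compound 4 (0.01 log units; within the scatter). In this assay compound 4 is estimated at 3.4 ug/mL, with a likely range from 1.7 ug/mL to 6.8 ug/mL.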

Compound 4, concentration for 50% inhibition: 3.4 ug/mL
Estimate against measurement, compound 4: no gap at the digits printed; low and high end bracket the measured number.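

In this assay, putting hydrogen in place of ethynyl on the saturated chain carbon bound to a sulfur gave a 1.0-fold higher number from compound 3 to compound 4 (0.01 log units; within the scatter). Set beside the same change on the carbon bound to a selenium atom, the two steps agree: the same change on two cores in this assay, a 1.1-fold lower number (0.04 log units; within the scatter) from compound 2 to compound 1 and a 1.0-fold higher number (0.01 log units; within the scatter) from compound 3 to compound 4, 1.1-fold (0.05 log units) apart, within the scatter of two such steps This shows that the change left the number within the scatter on both cores, but it does not show that the same would hold on any other core, and a change with no measurable effect here cannot show whether a real effect would carry over.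

The compounds shown leave open what a longer chain or an amine in place of propargyl or methyl would do to the number.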